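The source may report more compounds than this note shows. Statements on the series, on what has been measured and on what is new or still open speak of the compounds shown alone.

Measured compounds:
Compound 1, `CC(=O)c1cccc(-c2ccc(C(=O)N(Cc3cccc(OCCCCCC(=O)O)c3)C(C)C)cc2)c1`: in an ADME assay on Raji cells (Homo sapiens) for cytotoxicity, read by CellTiter-Glo and resazurin assay, with a stated time of 72 h (a higher number here means that more compound is needed for the effect, a lower number that less compound is needed), compound 1 gives > 26000 nM, a limit of the assay.
Compound 2, `CCOC(=O)CCCCCOc1cccc(CN(C(=O)c2ccc(-c3cccc(C(C)=O)c3)cc2)C(C)C)c1`: in this assay compound 2 gives > 26000 nM, a limit of the assay.
Compound 3, `CCOC(=O)CCCCCOc1cccc(CN(C(=O)c2ccc(-c3cc4ccccc4n3S(=O)(=O)c3ccccc3)cc2)C(C)C)c1`: in this assay compound 3 gives > 26000 nM, a limit of the assay.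

Compound 2 stands where every measured member of the series stands: at a limit, with no number behind it. Within the data shown here, the single measured step that reaches it, a step that the two limits leave unreadable from compound 1 to compound 2, cannot be sized because the limit of > 26000 nM in this assay, at which 3 of the 3 values shown sit, covers both of its ends.

Compound 4, `CCOC(=O)CCCCCOc1cccc(CN(C(=O)c2ccc(-c3cccc(Br)c3)cc2)C(C)C)c1`, is not yet measured. It differs from compound 2 by bromo in place of acetyl on an aromatic carbon: acetyl leaves and bromo enters on an aromatic carbon of a six-membered aromatic ring of carbon only. Among the measured compounds shown here, no measured step bears on this change directly; the only step in the set, a step that the two limits leave unreadable from compound 1 to compound 2, concerns a different part of the molecule and is itself unreadable. Compound 3 also sits at the limit. The measured steps give neither direction nor size, so no step beyond the scatter is expected, and a further limit is the most likely outcome. The expected step is a step that the limit leaves unreadable from compound 2 to compound 4. For compound 4 the estimate in this assay is 30000 nM, with a range from 12000 nM to 100000 nM.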

Compound 4, half-maximal effective concentration: > 26000 nM
Compound 4: a limit, no number; the forecaster's own chance of this, stated with the estimate: 85%; the middle value lies beyond the limit too.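

The change from compound 2 to compound 4, bromo in place of acetyl on an aromatic carbon, gives no readable step, because both compounds sit at a limit rather than at a number: the limit of > 26000 nM in this assay, at which 4 of the 4 values shown sit.

The compounds shown leave open whether any change to the shared core would bring a value within the readable range of this assay.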